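From Chloro to Hydroxy: Toxicity on Human Cells

A few compounds are considered here, and "the series" means these few. Any claim that something is new, unique, unknown or untested is made for them only; others in the source may bear on it.

Three compounds sharing one core have been examined in an ADME assay on HEL cells (Homo sapiens) for cytotoxicity, read by microscopy; on this read-out higher numbers stand for lower toxicity in this test and lower numbers for higher toxicity in this test. Compound 1 has the structure `O=C(N/N=C/c1cccc(Cl)c1)c1cccnc1`. In this assay compound 1 gives > 100 ug/mL, which is a limit of the assay rather than a number. Compound 2, `O=C(N/N=C/c1ccc(Br)cc1)c1cccnc1`, carries bromo in place of chloro. Compound 2 also reaches only the limit of > 100 ug/mL. Compound 3, `O=C(N/N=C/c1ccc([N+](=O)[O-])cc1)c1cccnc1`, shows >= 0.8 ug/mL, again a limit and not a number. The step that the two limits leave unreadable from compound 2 to compound 3 gives no size to work with, since both ends sit at limits: the limit of > 100 ug/mL in this assay, at which 2 of the 3 values shown sit, and (the limit of >= 0.8 ug/mL in this assay, at which 1 of the 3 values shown sits). Compound 1 therefore stands at the limit shared by two of the three values, with no number of its own.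

Compound 4, `O=C(N/N=C/c1cccc(O)c1)c1cccnc1`, has not yet been measured. It differs from compound 1 in one place: hydroxy in place of chloro on an aromatic carbon. For the measured compounds named here, no measured step involves hydroxy, and the one step available, from bromo to nitro, cannot be read, so nothing shows whether this exchange shifts the read-out. The expectation for compound 4 rests on compound 1 alone, whose value > 100 ug/mL is a limit. Compound 4 is therefore expected to give about 100 ug/mL, within 40 ug/mL to 100 ug/mL, a step of a number no higher from compound 1 to compound 4 (the limit leaves the size open) expected to stay within the scatter.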

Compound 4, minimum cytotoxic concentration: > 100 ug/mL
Compound 4 gave a limit, no number (the forecaster's own chance of this, stated with the estimate: 85%); the middle value lies on the limit itself.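

The step from compound 1 to compound 4 cannot be read, since each of the two compounds gives a limit of the assay and not a number: the limit of > 100 ug/mL in this assay, at which 3 of the 4 values shown sit.

The compounds shown leave open whether hydroxy in place of chloro shifts the read-out in this assay at all, and by how much, since neither group comes with a number here.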